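The compounds below may be only part of what the source reports. "The series", "measured", "known", "first", "only" and "open" are said of these compounds alone.

Measured in a functional assay on the whole organism for inhibition, with Scenedesmus acutus as the target, with a stated time of 20 min; on this read-out lower numbers stand for stronger inhibition and higher numbers for weaker inhibition:

Compound 1 `O=c1c2c(sn1-c1ccc(C(F)(F)F)cc1)CCCC2`: 74100 nM
Compound 2 `O=c1c2c(sn1-c1cc(OC3CCCC3)c(Cl)cc1F)CCCC2`: 12900 nM
Compound 3 `O=c1c2c(sn1-c1ccc(Cl)cc1)CCCC2`: 20400 nM

Compound 3 gives the second highest of the three numbers in this assay. Its nearest neighbour is compound 2, whose value sits within the scatter of that of compound 3, so the two cannot be ordered. For the measured compounds named here, its furthest neighbour is compound 1, and the single step between them, a 3.6-fold lower number from compound 1 to compound 3 (0.56 log units; beyond the scatter), is the only one-place change among the measured compounds.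

Compound 4 `O=c1c2c(sn1-c1ccc(Cl)cc1F)CCCC2` is the next compound to be measured. It differs from compound 3 in one place:

fluoro in place of hydrogen on an aromatic carbon

Going by the values given here, no measured step bears directly on this change. The step from compound 1 to compound 3 concerns a different group and does not involve fluoro. Compound 2 carries a fluoro in the same place as compound 4 does, but it also carries a cyclopentyloxy group, so its value against that of compound 3 mixes two changes and speaks only weakly for a small, favourable effect of the fluoro.

Given this, compound 4 is expected to show a step of about a 1.4-fold lower number from compound 3 to compound 4 (0.13 log units; within the scatter) in this assay, that is, little change beyond the scatter. The estimate for compound 4 is 15000 nM, with a range from 6000 nM to 40000 nM.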

Compound 4, half-maximal inhibitory concentration: 30200 nM
Beside the measured number, compound 4's estimate is 2.0-fold (0.30 log units) below it; measured number inside the range.
By their numbers in this assay, from the lowest: compounds 2, 3 and 4 (each within the scatter of the next, the first and the last beyond it); then compound 1.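

In this assay, fluoro in place of hydrogen on an aromatic carbon, ortho to a large group and meta to a chloro group, gives a 1.5-fold higher number from compound 3 to compound 4 (0.17 log units; within the scatter), so this single change does not separate the two compounds, and the small favourable effect hinted at by compound 2 finds no support here. For the compounds shown here, the cyclopentyloxy group can now be read on its own for the first time, since hydrogen in its place gives a 2.3-fold higher number from compound 2 to compound 4 (0.37 log units; beyond the scatter); with the fluoro held constant, the lower number of compound 2 therefore goes with the cyclopentyloxy group, although the effect is modest. Nothing available explains either step.

The compounds shown leave open whether the fluoro would remain equally silent with trifluoromethyl in place of the chloro, as in compound 1, since that pairing appears in none of them. They also leave open whether the modest gain belongs to the cyclopentyloxy group in particular or would also appear with a methoxy group, a longer alkoxy chain such as butoxy, or an amine on the same carbon.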